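Propoxy to ethoxy: from compound 1 to compound 3

The source may hold more compounds than are shown below. What is called first, only, known or untested is meant among the compounds shown, and "the series" means these compounds.

In a functional assay on PC-3 cells (Homo sapiens) for inhibition, read by sulforhodamine B assay, with a stated time of 48 h, tested at 50 uM (on this read-out lower numbers stand for less inhibition of growth and higher numbers for more inhibition of growth at the one concentration tested), compound 1 (`CCCOc1ccc([C@@H]2CC(=O)c3cc(CC=C(C)C)c(OC)cc3O2)cc1`) gives 54% and compound 2 (`COc1ccc([C@@H]2C/C(=N/OCc3cn(-c4ccc(O)cc4)nn3)c3cc(CC=C(C)C)c(OC)cc3O2)cc1`) gives 64% at the one concentration tested. These two values lie within the usual scatter of each other, so the numbers in hand draw no order between them.

The next compound is compound 3 (`CCOc1ccc([C@@H]2CC(=O)c3cc(CC=C(C)C)c(OC)cc3O2)cc1`), which differs from compound 1 by hydrogen in place of methyl on a saturated chain carbon, two bonds along the chain from an oxygen on an aromatic ring in a single place. This is hydrogen in place of methyl on a saturated chain carbon, two bonds along the chain from an oxygen on an aromatic ring, so propoxy becomes ethoxy while the rest of the structure stays the same.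

For the measured compounds named here, no pair of measured compounds shows this change on its own, so the data give no direct size for it. In this assay no step beyond the scatter is expected and no direction is favoured. The estimated a number 2 percentage points lower from compound 1 to compound 3 (within the scatter) is therefore small, and the expectation is anchored on compound 1 at 54% alone. For compound 3 the estimate is 52% with an expected range of 40% to 64% on measurement.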

Compound 3, percent growth inhibition at one concentration: 60%
For compound 3 the middle estimate is 8 percentage points below the measured one, within the range that was stated.
By their numbers in this assay, from the lowest: compounds 1, 3 and 2 (each within the scatter of the next).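

Propoxy to ethoxy gives the series its first step read at a single place: in this assay, the step is a number 6 percentage points higher from compound 1 to compound 3 (within the scatter). On a saturated chain carbon, two bonds along the chain from an oxygen on an aromatic ring, hydrogen in place of methyl therefore leaves two compounds that this read-out cannot tell apart at the one concentration tested, though this rests on one pair alone and says nothing about other places on the shared core. Nothing available bears on the size of this step.

For the compounds shown here, compound 2 differs from compound 1 and from compound 3 in more than one place, so no step to it can be read, and the part its oxime ether and triazole side chain may play stays unresolved. From the compounds shown here alone, it also stays open whether the same reading would hold for a longer chain such as butoxy, or for a chain ending in an amine or a carboxylic acid, at this same place on the core of compound 1.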